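The compounds below may be only part of what the source reports. "The series", "measured", "known", "first", "only" and "open" are said of these compounds alone.

Among the compounds with values here, in an ADME assay on CEM-SS cells (Homo sapiens) for cytotoxicity, read by XTT assay, with a stated time of 6 days (a higher number here means that more compound is tolerated, a lower number that less compound is tolerated), compound 2 `CCCC(=O)OCSc1ccccc1C(=O)NCCCCNC(C)=O` gives 17.4 uM, the only true number so far. Compound 1 `CCCC(=O)OCSc1ccccc1C(=O)NC1(C(N)=O)CCCC1` reads > 100 uM, which is a limit of the assay. Compound 3 `CCCC(=O)OCSc1ccccc1C(=O)N[C@@H]1CCC[C@@H]1C(N)=O` is still unmeasured and differs from compound 2 by 2-carbamoylcyclopentyl in place of 4-acetamidobutyl on an amide-type nitrogen. Within the data shown here, the one measured step that bears on this is an at least 5.7-fold lower number from compound 1 to compound 2 (0.75 log units; beyond the scatter), where 4-acetamidobutyl replaced 1-carbamoylcyclopentyl. Since the incoming group is a close relative of the one lost there, a partial reversal is expected, estimated as a 3.4-fold higher number from compound 2 to compound 3 (0.54 log units; beyond the scatter). Compound 3 is expected at 60 uM, within an estimated range of 20 uM to 180 uM.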

Compound 3, half-maximal toxic concentration: 90 uM
Compound 3: the middle estimate sits 1.5-fold (0.18 log units) below what was measured, and the stated range covers the measured number.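

Set on the amide-type nitrogen in this assay, 2-carbamoylcyclopentyl gives a 5.2-fold higher number from compound 2 to compound 3 (0.71 log units; beyond the scatter), so compound 2 stands apart from both carbamoyl-bearing cyclopentyl compounds. Exchanging 1-carbamoylcyclopentyl for 2-carbamoylcyclopentyl gives an at least 1.1-fold lower number from compound 1 to compound 3 (0.04 log units; that floor lies within the scatter), which does not tell the two groups apart. The true size of that step stays unread because compound 1 is a limit and not a number: the limit of > 100 uM in this assay, at which 1 of the 3 values shown sits.

On these data alone, whether the ring or the carbamoyl group carries the difference remains open, as does the part played by the two defined stereocentres of compound 3. A carboxylic acid or an amine in place of the carbamoyl group on the cyclopentyl ring remains untested among the compounds shown.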